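The source may hold more compounds than are shown below. What is called first, only, known or untested is meant among the compounds shown, and "the series" means these compounds.

In an ADME assay on L6 cells (Rattus norvegicus) for cytotoxicity, read by resazurin assay, with a stated time of 72 h (a higher number here means a weaker inhibitor, a lower number a stronger inhibitor), compound 1 (`NC1CC2(N3CCCC3)CC(c3ccccc3)C1C(c1ccccc1)C2`) gives 38100 nM and compound 3 (`NCC(=O)OC1CC2(N3CCCC3)CC(c3ccccc3)C1C(c1ccccc1)C2`) gives 42900 nM as its value. Compound 2 (`CN1CCN(CCC(=O)NC2CC3(N(C)C)CC(c4ccccc4)C2C(c2ccccc2)C3)CC1`) gives 95000 nM as its value, so compound 3 sits with compound 1 on the lower side of the three numbers and well short of compound 2.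

Compound 4 (`CN1CCN(CCC(=O)NC2CC3(N4CCCC4)CC(c4ccccc4)C2C(c2ccccc2)C3)CC1`) has not been measured. In it, ((2-(4-methylpiperazin-1-yl)ethyl)carbonyl)amino stands in place of ((aminomethyl)carbonyl)oxy on a saturated ring carbon (((2-(4-methylpiperazin-1-yl)ethyl)carbonyl)amino in place of ((aminomethyl)carbonyl)oxy on a saturated ring carbon).

One measured change at this ring carbon bears on it: a 1.1-fold higher number from compound 1 to compound 3 (0.05 log units; within the scatter) shows that replacing amino with the ester group moved the number no further than the scatter. Compound 2 already carries the entering group and gives 95000 nM in this assay as its value, which points upward. A modest rise is therefore expected, about the size of the scatter, and the expected change is a 1.4-fold higher number from compound 3 to compound 4 (0.15 log units; within the scatter) in all. For compound 4 the estimated value is 60000 nM with an expected range from 28000 nM to 125000 nM in this measurement.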

Compound 4, half-maximal inhibitory concentration: 86700 nM
Estimate against measurement, compound 4: 1.4-fold (0.16 log units) below, within the range that was stated.
By their numbers in this assay, from the lowest: compounds 1 and 3 (each within the scatter of the next); then compounds 4 and 2 (each within the scatter of the next).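

In this assay, the ((2-(4-methylpiperazin-1-yl)ethyl)carbonyl)amino group gives the steps at this position that lie beyond the scatter, though both are modest (a 2.0-fold higher number from compound 3 to compound 4 (0.31 log units; beyond the scatter); a 2.3-fold higher number from compound 1 to compound 4 (0.36 log units; beyond the scatter)), whereas the ester group had left the number within the scatter (a 1.1-fold higher number from compound 1 to compound 3 (0.05 log units; within the scatter)). With this group in place, exchanging dimethylamino for pyrrolidin-1-yl on a saturated ring carbon stays within the scatter (a 1.1-fold lower number from compound 2 to compound 4 (0.04 log units; within the scatter)). Nothing measured here explains the rise in the number.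

The step from the ester changes the linking atom and the chain together, so the compounds shown do not separate the two. They also leave open how a morpholine ring in place of the 4-methylpiperazine ring, or a shorter chain to that ring, would read at this carbon.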